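A few compounds are considered here, and "the series" means these few. Any claim that something is new, unique, unknown or untested is made for them only; others in the source may bear on it.

Two thiocarbamate esters of the same chromone-type scaffold open the series, both tested in a functional assay on SW480 cells (Homo sapiens) for antiproliferative activity, read by MTT assay, with a stated time of 72 h; a lower number here means a stronger inhibitor, a higher number a weaker inhibitor. Compound 1 `Cc1ccc2c(=O)c(CSC(=S)N3CCCCC3)coc2c1` gives > 25000 nM, which is a limit of this assay and not a number, so that compound 1 sits at the limit of > 25000 nM in this assay, at which 1 of the 2 values shown sits. Within the data shown here, compound 2 `O=c1c(CSC(=S)N2CCOCC2)coc2cc(Cl)ccc12`, with a morpholine on the thiocarbonyl carbon and a chlorine on the aromatic part, gives 6200 nM in this assay; among the values shown, compound 2 holds the only real number.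

Compound 3 `O=c1c(CSC(=S)N2CCCCC2)coc2cc(Cl)ccc12` has not yet been measured. It is made from compound 2 by one change, (piperidin-1-yl in place of morpholin-4-yl on a thiocarbonyl carbon), so that piperidin-1-yl takes the place of morpholin-4-yl on the thiocarbonyl carbon. Among the measured compounds shown here, no measured pair in this set isolates that exchange, so the size of the step can only be guessed. Compound 1 also carries the piperidin-1-yl group and reaches only a limit, which leaves room for some loss. Compound 3 is therefore expected to be somewhat weaker than compound 2, with an estimated step of a 1.5-fold higher number from compound 2 to compound 3 (0.16 log units; within the scatter). For compound 3 the estimate in this assay is 9000 nM, with a plausible range from 3000 nM to 30000 nM.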

Compound 3, half-maximal inhibitory concentration: 790 nM
Compound 3: the middle estimate sits 11-fold (1.06 log units) above what was measured; the measured number lies below the stated range.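

In this assay, among these compounds, the step for piperidin-1-yl in place of morpholin-4-yl on the thiocarbonyl carbon is a 7.8-fold lower number from compound 2 to compound 3 (0.89 log units; beyond the scatter), which shows for the first time that the group at this place alone can move the read-out beyond the scatter. With piperidin-1-yl held constant, the step for chloro in place of methyl on an aromatic carbon is an at least 31-fold lower number from compound 1 to compound 3 (1.50 log units; beyond the scatter), so the aromatic substituent also matters, and compound 3 combines the piperidin-1-yl group with chloro. Compound 1 is recorded only as a limit of the assay, not as a number, so the second step has no fixed size: the limit of > 25000 nM in this assay, at which 1 of the 3 values shown sits.

The compounds shown leave open whether other groups on the thiocarbonyl carbon, such as a diethylamino group or a piperazine, would match piperidin-1-yl, and whether the gap between piperidin-1-yl and morpholin-4-yl would hold with methyl rather than chloro on the aromatic carbon. From the compounds shown here alone, it is equally open whether bromo or methoxy in place of chloro would keep the value of compound 3, and these values give no cause for either step.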